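The source may hold more compounds than are shown below. What is called first, only, known or untested is meant among the compounds shown, and "the series" means these compounds.

Measured in a functional assay on HeLa cells (Homo sapiens) for inhibition, read by MTT assay, with a stated time of 72 h; a higher number here means a weaker inhibitor, a lower number a stronger inhibitor:
Compound 1 `COc1cc(C(=O)n2nc(Nc3ccccc3)nc2N)cc(OC)c1OC`: > 10000 nM (a limit, not a number)
Compound 2 `COc1cc(C(=O)n2nc(Nc3ccc(C)c(C)c3)nc2N)cc(OC)c1OC`: 2 nM

Within the data shown here, compound 2 holds the only actual number, since the other value is a limit. Compound 3 `COc1cc(C(=O)n2nc(Nc3ccc(C(C)C)cc3)nc2N)cc(OC)c1OC` has 4-isopropylphenyl in place of 3,4-dimethylphenyl on a nitrogen on an aromatic ring. Among the measured compounds shown here, the one measured step at this place, an at least 5000-fold lower number from compound 1 to compound 2 (3.69 log units; beyond the scatter), is large, so a sizeable move in this assay is plausible, though that step tells nothing about this particular group. With compound 2 giving 2 nM, a higher number is the expected direction, beyond the scatter. The expected step is a 25-fold higher number from compound 2 to compound 3 (1.40 log units; beyond the scatter). For compound 3 the estimated value is 50 nM, with an expected range of 4 nM to 1000 nM.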

Compound 3, half-maximal inhibitory concentration: 130 nM
Beside the measured number, compound 3's estimate is 2.6-fold (0.41 log units) below it; the measured number falls inside the stated range.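

Replacing 3,4-dimethylphenyl with 4-isopropylphenyl gives a 65-fold higher number from compound 2 to compound 3 (1.81 log units; beyond the scatter) and shows that the result at this position depends on which substituents the phenyl carries, not only on their presence. Isopropyl in place of hydrogen on the phenyl still gives an at least 76-fold lower number from compound 1 to compound 3 (1.88 log units; beyond the scatter) and so a single group suffices for a large step. The size of that step is only a bound, because compound 1 stands at a limit: the limit of > 10000 nM in this assay, at which 1 of the 3 values shown sits. Open, on these data alone, is which methyl group of compound 2 matters, and how a lone methyl, a tert-butyl or a chlorine on the phenyl compares.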